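The Other Enantiomer of Compound 2

A few compounds are considered here, and "the series" means these few. Any claim that something is new, unique, unknown or untested is made for them only; others in the source may bear on it.

Compound 1 `C[C@@]1(C(F)(F)F)CN(c2cccc[n+]2[O-])c2cc(S(=O)(=O)c3ccccc3)ccc2O1`: 0.28 nM
Compound 2 `CC1(C(F)(F)F)CN(c2cccc[n+]2[O-])c2cc(S(=O)(=O)c3ccccc3)ccc2O1`: 0.54 nM
Compound 3 `CC1(C)CN(c2cccc[n+]2[O-])c2cc(S(=O)(=O)c3ccccc3)ccc2O1`: 4.1 nM

These numbers come from a functional assay with Cavia porcellus as the target; on this read-out lower numbers stand for stronger inhibition and higher numbers for weaker inhibition. Compound 2 holds the second highest of the three numbers: the step of a 1.9-fold higher number from compound 1 to compound 2 (0.29 log units; within the scatter) is within the scatter, while the step of a 7.6-fold higher number from compound 2 to compound 3 (0.88 log units; beyond the scatter) is a modest weakening with methyl in place of trifluoromethyl. Compound 4 `C[C@]1(C(F)(F)F)CN(c2cccc[n+]2[O-])c2cc(S(=O)(=O)c3ccccc3)ccc2O1` differs from compound 2 only in that (the two compounds have the same atoms and bonds; at least one stereo element is drawn with a configuration in one of them and without one in the other: 1 of 1 stereo elements differ; a stereocentre at a saturated ring carbon is drawn without a configuration in compound 2 and R in compound 4). The step that bears on this is a 1.9-fold higher number from compound 1 to compound 2 (0.29 log units; within the scatter), read together with the fact that one of compounds 1 and 2 is drawn with a defined configuration and the other without, at the place where they differ, which means compound 2 is a mixture of both configurations and its number sits close to that of compound 1. Compound 4 is therefore expected to be the weaker configuration, with a step of a 28-fold higher number from compound 2 to compound 4 (1.44 log units; beyond the scatter). Compound 4 is estimated at 15 nM, ranging from 2 nM to 150 nM.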

Compound 4, half-maximal inhibitory concentration: 0.68 nM
For compound 4 the middle estimate is 22-fold (1.34 log units) above the measured one; the measured number lies below the stated range.
By their numbers in this assay, from the lowest: compounds 1, 2 and 4 (each within the scatter of the next, the first and the last beyond it); then compound 3.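

In this assay, the configuration at this saturated ring carbon counts for only a modest difference, with a 2.4-fold higher number from compound 1 to compound 4 (0.39 log units; beyond the scatter), so the R form keeps most of the activity of the S form. That gap can be put down to configuration alone because nothing else separates the two compounds: the fact that compounds 1 and 4 differ only in the configuration as drawn. The undefined compound also cannot be told apart from the R form, with a 1.3-fold higher number from compound 2 to compound 4 (0.10 log units; within the scatter).

From the compounds shown here alone, it remains open whether the two configurations would stay this close with an ethyl or a hydroxymethyl group in place of trifluoromethyl.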